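Tetrazolyl for carboxy on the chain acid

The source may hold more compounds than are shown below. What is called first, only, known or untested is meant among the compounds shown, and "the series" means these compounds.

Compound 3 `CC(CCC(=O)O)Cc1ccc(OCc2ccc3ccccc3n2)cc1` gives 43 nM in an assay on membranes from lung (Cavia porcellus) for binding affinity to cysteinyl leukotriene receptor (Homo sapiens); on this read-out lower numbers stand for stronger inhibition and higher numbers for weaker inhibition. Compound 1 `CC(CCc1nnn[nH]1)Cc1ccc(OCc2ccc3ccccc3n2)cc1` differs from it by 1H-tetrazol-5-yl in place of carboxy on a saturated chain carbon, four bonds along the chain from an aromatic carbon; in this assay compound 1 gives 12 nM, and the step is a 3.6-fold lower number from compound 3 to compound 1 (0.55 log units; beyond the scatter). Compound 2 `O=C(O)CCC(Cc1cccc(OCc2ccc3ccccc3n2)c1)c1ccccc1` has a different core, and the difference between the two cores is not broken down here; in this assay compound 2 gives 52 nM. Compound 4 `c1ccc(C(CCc2nnn[nH]2)Cc2cccc(OCc3ccc4ccccc4n3)c2)cc1` is reached from compound 2 by 1H-tetrazol-5-yl in place of carboxy on a saturated chain carbon, three bonds along the chain from an aromatic carbon. This is the same kind of change as from compound 3 to compound 1, not the same: there the place is four bonds along the chain from an aromatic carbon, here three bonds along the chain from an aromatic carbon. Compound 4 is expected at 15 nM in this assay, a step of a 3.5-fold lower number from compound 2 to compound 4 (0.54 log units; beyond the scatter) that rests on compound 1 and its step of a 3.6-fold lower number from compound 3 to compound 1 (0.55 log units; beyond the scatter).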

Compound 4, inhibition constant: 14 nM
Beside the measured number, compound 4's estimate is 1.1-fold (0.03 log units) above it; the range from low to high includes it.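

In this assay the exchange of carboxy for 1H-tetrazol-5-yl carries over to the second core, giving a 3.7-fold lower number from compound 2 to compound 4 (0.57 log units; beyond the scatter), and the two steps agree: the same change on two cores in this assay, a 3.6-fold lower number (0.55 log units; beyond the scatter) from compound 3 to compound 1 and a 3.7-fold lower number (0.57 log units; beyond the scatter) from compound 2 to compound 4, 1.0-fold (0.02 log units) apart, within the scatter of two such steps. On these two cores the step keeps its size although the place differs, four bonds along the chain from an aromatic carbon on one and three bonds along the chain from an aromatic carbon on the other. This rests on one pair per core in a single read-out, so it does not show that the step holds on other cores, nor what sets its size.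

The compounds shown leave open whether an acylsulfonamide or a hydroxamic acid in place of carboxy would give a similar step. Also open, from the compounds shown here alone, is whether the step survives on a longer chain.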